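This account rests on a few compounds, and the source may have more. Where it says the series, first, only, none or still open, it means among the compounds named here.

Working notes on the series.

Compound 2 `COc1ccccc1N1CCN(C(=O)CCN2C(=O)CSc3ccccc32)CC1` and compound 1 `O=C(CCN1C(=O)CSc2ccccc21)N1CCN(c2ccc(C(F)(F)F)cc2)CC1` share one core and differ in a single place, (4-(trifluoromethyl)phenyl in place of 2-methoxyphenyl on an amine nitrogen in a ring). In a functional assay on MDA-MB-231 cells (Homo sapiens) for inhibition, read by sulforhodamine B assay, with a stated time of 48 h (a higher number here means a weaker inhibitor of growth, a lower number a stronger inhibitor of growth), compound 2 gives 6600 nM, while compound 1 gives 1000 nM; the step is a 6.6-fold lower number from compound 2 to compound 1 (0.82 log units; beyond the scatter).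

Compound 3 `COc1ccccc1N1CCN(CCCNC(=O)CCN2C(=O)CSc3ccccc32)CC1` is built on a different core from compound 2; the difference between the two cores is not broken down here. In this assay compound 3 gives 2000 nM, which lies within the scatter of compound 1 and beyond the scatter relative to compound 2.

Compound 4 `O=C(CCN1C(=O)CSc2ccccc21)NCCCN1CCN(c2ccc(C(F)(F)F)cc2)CC1`, not yet measured, stands to compound 3 as compound 1 stands to compound 2: the change is 4-(trifluoromethyl)phenyl in place of 2-methoxyphenyl on an amine nitrogen in a ring, the same change in the same place, so the pair gives a second occurrence of the change already seen once.

For the measured compounds named here, the step in this assay is expected to be a 4.4-fold lower number from compound 3 to compound 4 (0.65 log units; beyond the scatter), a little smaller than the precedent, because the single precedent is a 6.6-fold lower number from compound 2 to compound 1 (0.82 log units; beyond the scatter) and a second core is untested. Compound 4 is therefore expected to give about 450 nM, with a range from 150 nM to 1500 nM.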

Compound 4, concentration for 50% growth inhibition: 20400 nM
Compound 4: middle estimate off by 45-fold (1.66 log units), on the low side; the whole stated range lies below it.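

In this assay the change gives a 10-fold higher number from compound 3 to compound 4 (1.01 log units; beyond the scatter), which runs opposite to the earlier step on the core of compound 2. The two steps do not agree: the same change on two cores in this assay, a 6.6-fold lower number (0.82 log units; beyond the scatter) from compound 2 to compound 1 and a 10-fold higher number (1.01 log units; beyond the scatter) from compound 3 to compound 4, 67-fold (1.83 log units) apart, beyond the scatter of two such steps. In this series, then, the effect of putting 4-(trifluoromethyl)phenyl in place of 2-methoxyphenyl does not carry from one core to the other, and even its direction depends on the core; with a single pair on each core, this does not show which part of the difference between the cores is responsible, nor how the change would behave on any further core.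

The compounds shown leave open whether a shorter or longer chain in the core of compound 3 and compound 4 would keep this reversal or restore the direction seen from compound 2 to compound 1. They also leave open how an unsubstituted phenyl on the same amine nitrogen in the ring would stand on each of the two cores.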